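The source may hold more compounds than are shown below. What is called first, only, known or untested is meant among the compounds shown, and "the series" means these compounds.

In an ADME assay on microsomes from liver (Homo sapiens) for pharmacokinetics, read by LC-MS, with a stated time of 60 min, tested at 1 uM (on this read-out higher numbers stand for fast clearance and lower numbers for slow clearance), compound 2 `O=C(NCc1ccc(S(=O)(=O)C2CCC(F)(F)CC2)cc1)N1Cc2ccncc2C1` gives 6 mL/min/kg, compound 1 `O=C(NCc1ccc(S(=O)(=O)c2cc(F)cc(F)c2)cc1)N1Cc2ccncc2C1` gives 8 mL/min/kg and compound 3 `O=C(NCc1ccc(S(=O)(=O)C2CCCOC2)cc1)N1Cc2ccncc2C1` gives 7 mL/min/kg, so compound 2 stands level with both others within the usual scatter. Compound 4 `O=C(NCc1ccc(S(=O)(=O)N2CCOCC2)cc1)N1Cc2ccncc2C1` has not yet been measured, and it differs from compound 2 as follows: morpholin-4-yl in place of 4,4-difluorocyclohexyl on a sulfonyl sulfur. This is morpholin-4-yl in place of 4,4-difluorocyclohexyl on a sulfonyl sulfur. Three measured steps change the group at that same place: a 1.3-fold lower number from compound 1 to compound 2 (0.12 log units; within the scatter), a 1.1-fold lower number from compound 1 to compound 3 (0.06 log units; within the scatter) and a 1.2-fold higher number from compound 2 to compound 3 (0.07 log units; within the scatter). For the measured compounds named here, all three lie within the scatter, although no measured compound has nitrogen on that sulfur. No step beyond the scatter is therefore expected, in either direction. The expected result is a 1.2-fold higher number from compound 2 to compound 4 (0.07 log units; within the scatter). For compound 4 the estimated value is 7 mL/min/kg, with an expected range from 4 mL/min/kg to 14 mL/min/kg.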

Compound 4, clearance: 9 mL/min/kg
Compound 4: middle estimate off by 1.3-fold (0.11 log units), on the low side, and the stated range covers the measured number.
By their numbers in this assay, from the lowest: compounds 2, 3, 1 and 4 (each within the scatter of the next).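

In this assay, for the compounds shown here, morpholin-4-yl, the first group with nitrogen on the sulfonyl sulfur, stays within the scatter of all three groups with carbon there (a 1.5-fold higher number from compound 2 to compound 4 (0.18 log units; within the scatter); a 1.3-fold higher number from compound 3 to compound 4 (0.11 log units; within the scatter); a 1.1-fold higher number from compound 1 to compound 4 (0.05 log units; within the scatter)). Across these four compounds, then, neither the change of group nor the change of the atom on the sulfur gives a step beyond the scatter. Nothing at hand bears on this result. Still open, as far as these compounds go, is whether a longer chain, a carboxylic acid or an amine on that sulfur would give a step beyond the scatter.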